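Series notes: hydroxy replacing the aminoalkyl chain

This account rests on a few compounds, and the source may have more. Where it says the series, first, only, none or still open, it means among the compounds named here.

Measured so far in a functional assay on MCF7 cells (Homo sapiens) for inhibition, read by MTT assay, with a stated time of 72 h; a higher number here means a weaker inhibitor, a lower number a stronger inhibitor:
Compound 1 `CC(C)=CCC[C@H](C)c1ccc(C)cc1O` gives > 20000 nM; this value is a limit of the assay, not a number.
Compound 2 `CC(C)=CCC[C@H](C)c1ccc(C)c(CNCC2CCNCC2)c1O` gives > 20000 nM; this value is a limit of the assay.
Compound 3 `CC(C)=CCC[C@H](C)c1ccc(C)c(CNCCCCC(=O)O)c1O` gives > 20000 nM; this value is also a limit of the assay.

Compound 3 thus stands at the limit in this assay, and the same holds for the other two values shown, so that (the limit of > 20000 nM in this assay, at which 3 of the 3 values shown sit). Going by the values given here, the only single-point step among the measured compounds, a step that the two limits leave unreadable from compound 2 to compound 3, is one that two limits leave unreadable, and its size cannot be stated.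

Compound 4 `CC(C)=CCC[C@H](C)c1ccc(C)c(CO)c1O` is not yet measured. It differs from compound 3 as follows: hydroxy in place of (4-carboxybutyl)amino on a saturated chain carbon bound to an aromatic carbon. Among the compounds with values here, no measured step bears readably on this change; the one step that exists gives no size and no direction. Within the data shown here, what the data do show is that every value in this assay so far is a limit, including that of compound 3.

On that basis compound 4 is expected to sit at or near the same limit, with the step that the limit leaves unreadable from compound 3 to compound 4 estimated as nothing beyond the scatter. For compound 4 the estimate in this assay is 30000 nM, expected within the range 10000 nM to 100000 nM.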

Compound 4, half-maximal inhibitory concentration: > 20000 nM
Compound 4 gave a limit, no number; the forecaster's own chance of this, stated with the estimate: 85%; the middle value does not contradict the limit.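

No new step can be read from compound 1, compound 2 or compound 3 to compound 4, and every value in this series is a limit, not a number: the limit of > 20000 nM in this assay, at which 4 of the 4 values shown sit.

The compounds shown leave open whether this assay can return a number for any change on the shared core, and the size and direction of every step among them.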